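Vinyloxy for Methylsulfonyl: Expected Maximal Response

A few compounds are considered here, and "the series" means these few. Any claim that something is new, unique, unknown or untested is made for them only; others in the source may bear on it.

Measured so far:
- compound 1 `CC(Oc1ccccc1OC1CC1)C1=NCCN1`: 0.7
- compound 2 `CC(Oc1ccccc1Br)C1=NCCN1`: 0.87
- compound 3 `CC(Oc1ccccc1S(C)(=O)=O)C1=NCCN1`: 0.6

In an assay on CHO cells with Alpha-2C adrenergic receptor (Homo sapiens) as the target (a higher number here means a larger maximal response, a lower number a smaller maximal response), compound 3 gives 0.6, the lowest of the three numbers. Its nearest neighbour is compound 1, the step a number 0.10 lower from compound 1 to compound 3 (within the scatter); its furthest is compound 2, the step a number 0.27 lower from compound 2 to compound 3 (beyond the scatter). Compound 1 and compound 2 differ by a number 0.17 higher from compound 1 to compound 2 (beyond the scatter). So the three compounds share one core and differ only in the group on one aromatic carbon, and the largest swing seen among them is modest.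

The next compound, compound 4 `C=COc1ccccc1OC(C)C1=NCCN1`, is reached from compound 3 by a single change: vinyloxy in place of methylsulfonyl on an aromatic carbon

The step that bears on this is a number 0.10 lower from compound 1 to compound 3 (within the scatter), where one oxygen-linked group stood in the position now taken by vinyloxy; that step stayed within the scatter. The bromo compound is the outlier at the high end, and vinyloxy is not bromo. A step of about the same size as from compound 3 to compound 1, upward, is therefore expected in this assay, roughly a number 0.10 higher from compound 3 to compound 4 (within the scatter). Compound 4 is estimated at 0.7, with a likely range from 0.55 to 0.85.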

Compound 4, intrinsic activity: the largest response reached, as a fraction of the reference agonist's: 0.48
Compound 4: the middle estimate sits 0.22 above what was measured; the whole stated range lies above it.
By their numbers in this assay, from the lowest: compound 4; then compounds 3 and 1 (each within the scatter of the next); then compound 2.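

In this assay the sharpest comparison is the one made on the oxygen itself, where vinyl in place of cyclopropyl gives a number 0.22 lower from compound 1 to compound 4 (beyond the scatter) and so shows that keeping an oxygen on the aromatic carbon does not fix the maximal response, since the group carried on that oxygen matters too. Vinyloxy in place of methylsulfonyl gives a number 0.12 lower from compound 3 to compound 4 (beyond the scatter) in the same assay, which means compound 4 now holds the lowest number of the set, with its steps to all three others printed as beyond the scatter, and the low end no longer belongs to methylsulfonyl. Vinyloxy in place of bromo gives a number 0.39 lower from compound 2 to compound 4 (beyond the scatter) as the one large step in the series, so this single aromatic position spans a wider range of maximal response than the first three compounds showed.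

No measurement among the data shown explains why the response moves in this way. As far as these compounds go, it remains open whether a plain methoxy, a longer chain such as propyloxy, or an amine on the same aromatic carbon would sit nearer compound 4 or nearer compound 2 in maximal response.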